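Furan to thiophene swap on a second core, adenosine A3 inhibition

The source may report more compounds than this note shows. Statements on the series, on what has been measured and on what is new or still open speak of the compounds shown alone.

Compound 1 `CCSC(=O)C1=C(C)NC(=O)NC1c1ccoc1` in an assay on membranes from HeLa cells for displacement of a labelled ligand from adenosine receptor A3 (Homo sapiens), read by scintillation counting, with a stated time of 180 min, tested at 1 uM (a lower number here means less inhibition, a higher number more inhibition at the concentration tested (going by the name of the read-out)), gives 1%. Compound 2 `CCSC(=O)C1=C(C)NC(=O)NC1c1cccs1` differs by thiophen-2-yl in place of furan-3-yl on a saturated ring carbon and in this assay gives 1%; the step of no change at the digits printed from compound 1 to compound 2 (within the scatter). Compound 3 `CC1=C(c2ncc(C)o2)C(c2ccoc2)NC(=O)N1` carries a different core, the difference being (5-methyl-1,3-oxazol-2-yl in place of (ethylsulfanyl)carbonyl on a double-bonded ring carbon); in this assay compound 3 gives 1%, and the step of no change at the digits printed from compound 1 to compound 3 (within the scatter). All three measured values sit at the same level.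

Compound 4 `CC1=C(c2ncc(C)o2)C(c2cccs2)NC(=O)N1` is not yet measured. It differs from compound 3 by thiophen-2-yl in place of furan-3-yl on a saturated ring carbon. This is the same kind of change as that from compound 1 to compound 2, though the place differs: in compound 3 the saturated ring carbon is next to the ring atom that bears a 5-methyl-1,3-oxazol-2-yl group, in compound 1 next to the ring atom that bears a (ethylsulfanyl)carbonyl group. On the first core the change produced no change at the digits printed from compound 1 to compound 2 (within the scatter); the step from compound 3 to compound 4 is therefore expected to be a number 1 percentage points higher from compound 3 to compound 4 (within the scatter). For compound 4 the expected value is 2%, estimated between 0% and 10%.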

Compound 4, a percentage reported as inhibition, at one concentration (the size of the read-out at that concentration, not a potency): 1%
Beside the measured number, compound 4's estimate is 1 percentage points above it; the measured number falls inside the stated range.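

In this assay, thiophen-2-yl in place of furan-3-yl on the saturated ring carbon gives no change at the digits printed from compound 3 to compound 4 (within the scatter), and this reads the same as on the core of compound 1: the same change on two cores in this assay, no change at the digits printed (within the scatter) from compound 1 to compound 2 and no change at the digits printed (within the scatter) from compound 3 to compound 4, 0 percentage points apart, within the scatter of two such steps. 5-methyl-1,3-oxazol-2-yl in place of (ethylsulfanyl)carbonyl gives no change at the digits printed from compound 2 to compound 4 (within the scatter), and this change also reads the same with either ring on the saturated carbon: the same change on two cores in this assay, no change at the digits printed (within the scatter) from compound 1 to compound 3 and no change at the digits printed (within the scatter) from compound 2 to compound 4, 0 percentage points apart, within the scatter of two such steps. Among the compounds shown here, this agreement shows only that neither change moves inhibition on either core at the concentration tested; with all four compounds at one level, it does not show that a step of real size would carry from one core to the other.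

Going by these compounds, what a phenyl ring on the saturated ring carbon, or a carboxylic acid in place of (ethylsulfanyl)carbonyl, would give in this assay stays open. Also open, on these data alone, is whether any group in these two places lifts the read-out clear of this level, which a real test of transfer between the cores would need.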